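Amide for Acid: Expecting the Response of Compound 4

The source may hold more compounds than are shown below. What is called first, only, known or untested is meant among the compounds shown, and "the series" means these compounds.

Measured so far:
compound 1, `O=C(CN(c1ncnc2c1ncn2C1CCCCO1)C1CC1)N[C@@H](CO)C(=O)OCc1ccccc1`, 18.3%
compound 2, `CSCC[C@H](NC(=O)CN(c1nc(Cl)nc2[nH]cnc12)C1CC1)C(=O)OCc1ccccc1`, 17.6%
compound 3, `O=C(O)CC[C@H](NC(=O)CN(c1nc(Cl)nc2[nH]cnc12)C1CC1)C(=O)O`, 29.5%

In a functional assay on the whole organism (Tail, strain ICR) with Mus musculus as the target, in the tail flick test, with a stated time of 150 min, at a dose of 25 umol/kg by the oral route (on this read-out lower numbers stand for a weaker effect and higher numbers for a stronger effect at the one dose given), compound 3 gives 29.5%, the highest of the three numbers. Compound 1 sits lower by a margin beyond the scatter, and compound 2 sits lower still, also beyond the scatter. These three compounds differ from one another in several places at once, so no single change among them can be read on its own.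

Compound 4, `NC(=O)CC[C@H](NC(=O)CN(c1nc(Cl)nc2[nH]cnc12)C1CC1)C(=O)O`, differs from compound 3 in exactly one place: amino in place of hydroxy on a carbonyl carbon. Among the measured compounds shown here, nothing among the measured compounds shows what such a change does in this test, so the expectation rests on the small size of the change alone. The step of a number 3.5 percentage points lower from compound 3 to compound 4 (within the scatter) is expected to be small, in either direction, and most likely within the usual scatter. Compound 4 is therefore expected to give about 26%, with a likely range from 12% to 40%.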

Compound 4, a percentage reported as activity, at one dose (the size of the read-out at that dose, not a potency): 11.4%
Estimate against measurement, compound 4: 14.6 percentage points above; the measured number lies below the stated range.
By their numbers in this assay, from the lowest: compounds 4, 2 and 1 (each within the scatter of the next); then compound 3.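

Replacing hydroxy with amino on a carbonyl carbon, which turns 2-carboxyethyl into 2-carbamoylethyl, gives a number 18.1 percentage points lower from compound 3 to compound 4 (beyond the scatter) in this assay and so is not a neutral exchange at this position. The effect at this one dose and time therefore depends on which group sits here, even though the two groups match in their counts of heavy atoms, hydrogen-bond donors and hydrogen-bond acceptors, and neither carries a net charge. Nothing at hand gives a reason for this step.

The compounds shown leave open whether the free carboxylic acid itself is what matters here, or whether a methyl ester, a nitrile or a tetrazole could stand in its place. They also leave open how a shorter carboxymethyl chain or a longer 3-carboxypropyl chain would compare with the 2-carboxyethyl group.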